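A Piperidin-1-yl Group on the Carbonyl of Compound 2

The source may hold more compounds than are shown below. What is called first, only, known or untested is meant among the compounds shown, and "the series" means these compounds.

Of the compounds shown here, two that share one core have been measured so far. In a functional assay with Oryctolagus cuniculus as the target (on this read-out higher numbers stand for weaker inhibition and lower numbers for stronger inhibition), compound 1 `COc1ccc(-c2nc(CNC(=O)NC(C)C)sc2-c2ccc(OC)cc2)cc1` gives 42 nM. Compound 2 `COc1ccc(-c2nc(C(=O)N=C(N)N)sc2-c2ccc(OC)cc2)cc1` reads > 100 nM, and this is a limit of the assay, not a number. Its exact place on the scale is therefore unknown.

Compound 3 `COc1ccc(-c2nc(C(=O)N3CCCCC3)sc2-c2ccc(OC)cc2)cc1` keeps the shared core and the carbonyl of compound 2 but changes what that carbonyl carries: a group of 6 heavy atoms (5 carbon, 1 nitrogen; one six-membered non-aromatic ring with 1 hetero atom) in place of a group of 4 heavy atoms (1 carbon, 3 nitrogen; no ring), on a carbonyl carbon.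

Among the compounds with values here, only one measured step bears on this change: an at least 2.3-fold higher number from compound 1 to compound 2 (0.37 log units; beyond the scatter). It lies beyond the scatter, so altering this part of the molecule can shift the read-out. However, no measured compound carries a piperidin-1-yl group, and that step gives neither the size nor the direction of this new change. The expectation therefore stays close to the starting point, with a wide margin on both sides. In this assay, the expected step is a step that the limit leaves unreadable from compound 2 to compound 3, which is a rough estimate given that it starts from a limit. For compound 3, the estimated value is 150 nM, with an expected range from 40 nM to 600 nM.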

Compound 3, half-maximal inhibitory concentration: > 1000 nM
Compound 3 gave a limit, no number; the forecaster's own chance of this, stated with the estimate: 50%; middle value at least 6.6-fold (0.82 log units) away from the limit.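

In this assay compound 3 gives > 1000 nM, which is a limit of the assay and not a number. Within the data shown here, the one step that can be read is an at least 23-fold higher number from compound 1 to compound 3 (1.37 log units; beyond the scatter), with (piperidin-1-yl)carbonyl in place of ((isopropylcarbamoyl)amino)methyl on an aromatic carbon, so this position can move the read-out by far more than the first step showed, and a piperidin-1-yl group on the carbonyl does not return the level of compound 1. The step between compound 2 and compound 3 cannot be read, since both ends are limits, so neither compound can be ranked against the other, although both now sit on the weaker side of compound 1.

The compounds shown do not separate the two things that differ between compound 1 and compound 3, the carbonyl set directly on the shared core and the loss of the isopropyl urea chain. An isopropylamino group on the same carbonyl would keep part of that chain on the carbonyl of compound 3 and could begin to tell these two apart.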